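This account rests on a few compounds, and the source may have more. Where it says the series, first, only, none or still open, it means among the compounds named here.

Working notes on the group carried on an aromatic carbon of the shared core, across compound 1 `O=C(O)c1cn(C2CC2)c2c(F)c(N3CCCC3)c(F)cc2c1=O`, compound 2 `CNCC1(C)CCN(c2c(F)cc3c(=O)c(C(=O)O)cn(C4CC4)c3c2F)C1` and compound 3 `CC1CN(c2c(F)cc3c(=O)c(C(=O)O)cn(C4CC4)c3c2F)CC(C)N1`. In a functional assay on V79 cells (Cricetulus griseus) for cytotoxicity, read by colony formation (a higher number here means a weaker inhibitor, a lower number a stronger inhibitor), compound 3 gives 150 ug/mL and compound 1 gives 120 ug/mL, within the scatter of each other, whereas compound 2 gives 8 ug/mL. Compound 3 thus sits at the high end of the series. Compound 4 `NC1CCCN(c2c(F)cc3c(=O)c(C(=O)O)cn(C4CC4)c3c2F)C1` differs from it by 3-aminopiperidin-1-yl in place of 3,5-dimethylpiperazin-1-yl on an aromatic carbon, with 3-aminopiperidin-1-yl in place of 3,5-dimethylpiperazin-1-yl. Among the measured compounds shown here, no measured step makes this exact exchange. The nearest evidence is mixed: a 1.3-fold higher number from compound 1 to compound 3 (0.10 log units; within the scatter), but a 19-fold higher number from compound 2 to compound 3 (1.27 log units; beyond the scatter) and a 15-fold lower number from compound 1 to compound 2 (1.18 log units; beyond the scatter). A moderate drop in this assay is therefore expected, smaller than the steps involving compound 2. The estimated step is a 3.3-fold lower number from compound 3 to compound 4 (0.52 log units; beyond the scatter). For compound 4, the expected value is 45 ug/mL, with an estimated range of 12 ug/mL to 160 ug/mL.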

Compound 4, half-maximal inhibitory concentration: 53 ug/mL
Compound 4: the middle estimate sits 1.2-fold (0.07 log units) below what was measured, and the stated range covers the measured number.
By their numbers in this assay, from the lowest: compound 2; then compound 4; then compounds 1 and 3 (each within the scatter of the next).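

In this assay, the exchange to 3-aminopiperidin-1-yl on this aromatic carbon gives a 2.8-fold lower number from compound 3 to compound 4 (0.45 log units; beyond the scatter) and a 2.3-fold lower number from compound 1 to compound 4 (0.35 log units; beyond the scatter), yet still a 6.6-fold higher number from compound 2 to compound 4 (0.82 log units; beyond the scatter). A six-membered non-aromatic ring alone therefore does not fix the number at this position, since compound 3 and compound 4 both carry one and differ beyond the scatter. Nothing available accounts for these steps. Open, as far as these compounds go, is where 3-aminopyrrolidin-1-yl would fall on the same carbon relative to compound 2 and compound 4. Also open, from the compounds shown here alone, is whether a methyl group on the 3-aminopiperidin-1-yl ring would shift the number.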